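The compounds below may be only part of what the source reports. "The series", "measured", "known", "first", "only" and "open" are said of these compounds alone.

Series notes, step from compound 1 to compound 4.

Compound 1 `COc1ccc(N2CCN(Cc3csc(N)c3C(=O)c3ccc(Cl)cc3)CC2)cc1` was tested in a functional assay on CHO cells with adenosine receptor A1 (Homo sapiens) as the target, read by cAMP accumulation and immunoassay, with a stated time of 6 min, tested at 0.01 uM (a higher number here means a weaker effect of the compound at the concentration tested, a lower number a stronger effect), and gives -1.2%. Within the data shown here, this is the highest of the three numbers measured so far. Compound 2 `Nc1scc(CN2CCN(c3cccc(C(F)(F)F)c3)CC2)c1C(=O)c1ccc(Cl)cc1` gives -8.2%, and the step of a number 7 percentage points lower from compound 1 to compound 2 (within the scatter) is within the scatter, so the two are not told apart. Compound 3 `Nc1scc(CN2CCN(c3ccc(C(F)(F)F)cc3)CC2)c1C(=O)c1cccc(C(F)(F)F)c1` gives -12%; compound 3 differs from compound 1 in two places, and the gap between their two values lies beyond the scatter, with compound 3 the lower.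

Compound 4 `Nc1scc(CN2CCN(c3ccc(F)c(F)c3)CC2)c1C(=O)c1ccc(Cl)cc1` is not yet measured. It differs from compound 1 in one place: 3,4-difluorophenyl in place of 4-methoxyphenyl on an amine nitrogen in a ring

Among the measured compounds shown here, the one measured step that bears on this change is the one from compound 1 to compound 2, where another aryl group replaced the 4-methoxyphenyl on the same amine nitrogen in a ring and gave a number 7 percentage points lower from compound 1 to compound 2 (within the scatter), a change inside the scatter. For the measured compounds named here, no measured step involves 3,4-difluorophenyl. On that basis, no step beyond the scatter is expected for this assay; the expected step is a number 2.8 percentage points lower from compound 1 to compound 4 (within the scatter).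

Compound 4 is therefore estimated at -4%, with the range -14% to 6%.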

Compound 4, a percentage reported as activity, at one concentration (the size of the read-out at that concentration, not a potency): -3.2%
For compound 4 the middle estimate is 0.8 percentage points below the measured one; the measured number falls inside the stated range.
By their numbers in this assay, from the lowest: compounds 3, 2, 4 and 1 (each within the scatter of the next, the first and the last beyond it).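

In this assay, the 3,4-difluorophenyl group on the amine nitrogen in a ring can be read against two neighbours: 4-methoxyphenyl (a number 2 percentage points lower from compound 1 to compound 4 (within the scatter)) and 3-(trifluoromethyl)phenyl (a number 5 percentage points higher from compound 2 to compound 4 (within the scatter)). The position now holds three aryl groups on an otherwise unchanged core, and neither new step leaves the scatter, so this assay does not tell the difluoro compound apart from either neighbour at the single concentration tested. The replacement of 4-methoxyphenyl also takes the hydrogen-bond acceptor count of the group from 1 to 0 with no step beyond the scatter, and nothing among the data available bears on why these values stay together.

The compounds shown leave open whether anything other than a substituted phenyl at this nitrogen, such as a benzyl group, a pyridine ring or a phenyl carrying a carboxylic acid, would give a step beyond the scatter. They also leave open how much of the gap for compound 3 belongs to each of the two places in which it differs from compound 1, since neither change is shown alone.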